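The compounds below may be only part of what the source reports. "The series", "measured", "known", "first", "only" and "open" are said of these compounds alone.

Compound 1 `CCOc1nc(N)c2nc(O)n(Cc3ccccc3)c2n1`: 0.1 uM; compound 2 `CCCCCOc1nc(N)c2nc(O)n(Cc3ccccc3)c2n1`: 0.01 uM.

In a functional assay (spleen, spleen) for activation, with Mus musculus as the target (a higher number here means that more compound is needed for the effect, a lower number that less compound is needed), compound 1 gives 0.1 uM and compound 2 gives 0.01 uM, so compound 2 stands lowest of the two, with compound 1 above it by a 10-fold lower number from compound 1 to compound 2 (1.00 log units; beyond the scatter). Compound 3 `CCCOc1nc(N)c2nc(O)n(Cc3ccccc3)c2n1` differs from compound 2 by hydrogen in place of ethyl on a saturated chain carbon, three bonds along the chain from an oxygen on an aromatic ring. For the measured compounds named here, the only step that bears on this is the one from compound 1 to compound 2, a 10-fold lower number from compound 1 to compound 2 (1.00 log units; beyond the scatter), where propyl entered on the same chain. Shortening the chain again by ethyl is expected to move the number partway back toward compound 1, so a step of a 3.0-fold higher number from compound 2 to compound 3 (0.48 log units; beyond the scatter) in this assay is expected. Compound 3 is therefore estimated at 0.03 uM, in the range 0.01 uM to 0.1 uM.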

Compound 3, minimum effective concentration: 0.01 uM
Compound 3: the middle estimate sits 3.0-fold (0.48 log units) above what was measured; measured number inside the range.
By their numbers in this assay, from the lowest: compounds 2 and 3 (each within the scatter of the next); then compound 1.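

In this assay, taking ethyl off the chain leaves no change at the digits printed from compound 2 to compound 3 (within the scatter), so pentyl and propyl cannot be told apart at this position. Adding a single methyl to the chain of compound 1 already gives a 10-fold lower number from compound 1 to compound 3 (1.00 log units; beyond the scatter), the same size of step as adding propyl. Nothing available here offers an explanation for this result.

From the compounds shown here alone, whether a longer chain such as heptyl would keep the number of compound 2 remains open. So does the effect of a branched chain such as isopropyl or of an amine at the chain end.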